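Chain length in a series of sulfonamide acids

The source may report more compounds than this note shows. Statements on the series, on what has been measured and on what is new or still open speak of the compounds shown alone.

Compound 1 `O=C(O)CCCCNS(=O)(=O)c1ccccc1` and compound 2 `O=C(O)CCCCCNS(=O)(=O)c1ccccc1` carry short chains; compound 3 `O=C(O)CCCCCCCCCCNS(=O)(=O)c1ccccc1` and the unmeasured compound 4 `O=C(O)CCCCCCCCCCCNS(=O)(=O)c1ccccc1` carry long ones. In a functional assay (aorta) for inhibition, with Rattus norvegicus as the target (a higher number here means a weaker inhibitor, a lower number a stronger inhibitor), compound 1 gives only a limit, > 140000 nM. Compound 2 likewise gives only a limit, > 140000 nM. Compound 3 gives 4600 nM. The change carboxymethyl in place of carboxy on a saturated chain carbon, four bonds along the chain from a sulfonamide nitrogen produced a step that the two limits leave unreadable from compound 1 to compound 2, which the limit of > 140000 nM in this assay, at which 2 of the 3 values shown sit, leaves unreadable. How the core of compound 3 differs from that of compound 1 is not broken down here. Compound 4 arises from compound 3 by carboxymethyl in place of carboxy on a saturated chain carbon, ten or more bonds along the chain from a sulfonamide nitrogen, the same kind of change as before. Because compound 3 gives 4600 nM, the measured compound of this kind, compound 4 is expected to stay near it, a 1.3-fold lower number from compound 3 to compound 4 (0.12 log units; within the scatter), with an estimated 3500 nM in this assay, between 1200 nM and 12000 nM.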

Compound 4, half-maximal inhibitory concentration: 6400 nM
Estimate against measurement, compound 4: 1.8-fold (0.26 log units) below; the measured number falls inside the stated range.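

In this assay the change gives a 1.4-fold higher number from compound 3 to compound 4 (0.14 log units; within the scatter), so on the long chain of compound 3 it leaves no readable difference. On the short chain the same change cannot be read, because compound 1 and compound 2 both give only a limit of the assay: the limit of > 140000 nM in this assay, at which 2 of the 4 values shown sit. The series therefore gives one readable outcome for this change, and it does not show that the step keeps its size from one core to another.

The compounds shown leave open how chains of intermediate length behave and whether a longer chain than that of compound 4 would read the same. They also leave open what an amide would give in place of the carboxylic acid.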